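Replacing the 2-fluorophenyl group of compound 1

The compounds below may be only part of what the source reports. "The series", "measured", "known", "first", "only" and "open" are said of these compounds alone.

Within the data shown here, in a functional assay on QG-56 cells (Homo sapiens) for antiproliferative activity (on this read-out higher numbers stand for weaker inhibition and lower numbers for stronger inhibition), compound 1 `Cn1cncc1C(O)(c1ccc(C#N)cc1)c1cc2cc([N+](=O)[O-])cc(-c3ccccc3F)c2o1` gives 89.5 nM, the lowest of the two exact numbers so far. Compound 2 `Cn1cncc1C(O)(c1ccc(C(=O)OC(C)(C)C)cc1)c1cc2cc([N+](=O)[O-])cc(-c3ccccc3)c2o1`, with a different group on the core, gives 6250 nM. Compound 3 `Cn1cncc1C(O)(c1ccc(C(=O)O)cc1)c1cc2cc([N+](=O)[O-])cc(-c3ccccc3)c2o1` is reported only as a limit, > 10000 nM. Among the measured compounds shown here, the single measured step, an at least 1.6-fold higher number from compound 2 to compound 3 (0.20 log units; that floor lies within the scatter), exchanges tert-butyl for hydrogen, so it does not involve the group that changes next.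

Compound 4 `Cc1cccc(-c2cc([N+](=O)[O-])cc3cc(C(O)(c4ccc(C#N)cc4)c4cncn4C)oc23)c1` carries 3-methylphenyl in place of 2-fluorophenyl on an aromatic carbon. For the measured compounds named here, no measured step covers this exchange, so the step between compound 2 and compound 3 gives no size to carry over. The best starting point is compound 1 itself at 89.5 nM, and no shift beyond the scatter is expected in this assay, though a move in either direction remains possible. The expected change is a 1.5-fold higher number from compound 1 to compound 4 (0.16 log units; within the scatter). The estimate for compound 4 is 130 nM, with an expected range from 30 nM to 550 nM.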

Compound 4, half-maximal inhibitory concentration: 23.2 nM
Estimate against measurement, compound 4: 5.6-fold (0.75 log units) above; the whole stated range lies above it.
By their numbers in this assay, from the lowest: compound 4; then compound 1; then compound 2. At a limit, above all of these: compound 3.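

The aryl group at this place on the shared core clearly affects the read-out in this assay: 3-methylphenyl in place of 2-fluorophenyl gives a 3.9-fold lower number from compound 1 to compound 4 (0.59 log units; beyond the scatter). This is the first step shown at this place, and the two groups have the same heavy-atom count, one six-membered aromatic ring of carbon only, no hydrogen-bond donors or acceptors, and no net charge, so these counts do not account for the shift. Nothing measured here gives a reason for it.

The step replaces fluorine with methyl and also shifts the substituent's place on the phenyl ring, and a single step cannot tell these two changes apart. As far as these compounds go, how 3-fluorophenyl, 2-methylphenyl, or a phenyl ring bearing a methoxy group or an amine would read at this place remains open.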